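The source may hold more compounds than are shown below. What is called first, only, known or untested is meant among the compounds shown, and "the series" means these compounds.

Measured compounds:
compound 1 `CN(C(=O)c1ccc(Cl)cc1)c1ccc2[nH]c(-c3n[nH]c4ccccc34)cc2n1` — 630 nM
compound 2 `CN(c1ccc2[nH]c(-c3n[nH]c4ccccc34)cc2n1)S(=O)(=O)c1ccccc1` — 2400 nM

For the measured compounds named here, in a functional assay on KB cells (Homo sapiens) for antiproliferative activity, read by MTT assay, with a stated time of 72 h (on this read-out higher numbers stand for weaker inhibition and lower numbers for stronger inhibition), compound 2 gives 2400 nM, the higher of the two numbers in hand; the single measured step, a 3.8-fold higher number from compound 1 to compound 2 (0.58 log units; beyond the scatter), is beyond the scatter and sets compound 2 apart as the weaker of the pair. Compound 3 is `CN(c1ccc2[nH]c(-c3n[nH]c4ccccc34)cc2n1)S(=O)(=O)c1ccc(OC(F)(F)F)cc1`, not yet measured. The change from compound 2 to compound 3 is trifluoromethoxy in place of hydrogen on an aromatic carbon. Going by the values given here, the one step measured so far exchanges the whole group on the ring nitrogen rather than adding a substituent to a retained phenyl, so it does not bear directly on this change, and no measured pair varies a substituent on the phenyl of the sulfonyl group. With nothing to anchor a direction, the expectation for compound 3 in this assay is a step of a 1.6-fold lower number from compound 2 to compound 3 (0.20 log units; within the scatter) that stays close to compound 2, within or only just beyond the scatter. Compound 3 is therefore estimated at 1500 nM, with a range from 500 nM to 5000 nM.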

Compound 3, half-maximal inhibitory concentration: 1330 nM
Compound 3: the middle estimate sits 1.1-fold (0.05 log units) above what was measured; measured number inside the range.
By their numbers in this assay, from the lowest: compound 1; then compounds 3 and 2 (each within the scatter of the next).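

In this assay, adding a substituent to the retained phenyl of the sulfonyl group, phenyl to 4-(trifluoromethoxy)phenyl, gives a 1.8-fold lower number from compound 2 to compound 3 (0.26 log units; within the scatter). For the compounds shown here, this is the first reading at this aromatic carbon, and it shows that a group of 5 heavy atoms can stand there, para to a large group, without a step beyond the scatter, whereas the earlier step exchanged the whole group on the ring nitrogen and could say nothing about a substituent on this phenyl. No measurement in hand offers an explanation for this result.

Going by these compounds, a single substituent gives no trend at this carbon, so it remains open whether an amine, a carboxylic acid or a longer alkyl chain there would produce a step beyond the scatter. Also open, on these data alone, is how a chlorine on the phenyl of the sulfonyl group would read, since that atom appears only on the carbonyl-linked phenyl of compound 1.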